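The source may report more compounds than this note shows. Statements on the series, on what has been measured and on what is new or still open speak of the compounds shown alone.

Compound 1 `O=C(CSC(=S)N[C@H]1CCOC1=O)Nc1cccc(Cl)c1` and compound 2 `O=C(CSC(=S)N[C@H]1CCOC1=O)Nc1ccccc1` share one core, while compound 3 `O=C(CCl)Nc1ccc(C(=O)/C=C/c2ccc(Cl)cc2)cc1` and compound 4 `O=C(CCl)Nc1ccc(C(=O)/C=C/c2ccccc2)cc1` share another; the difference between the two cores is not broken down here. In a functional assay on SMMC-7721 cells (Homo sapiens) for cytotoxicity, read by MTT assay, with a stated time of 72 h (a lower number here means a stronger inhibitor, a higher number a weaker inhibitor), compound 1 gives only a limit, > 128000 nM. Compound 2 likewise gives only a limit in this assay, > 128000 nM. The change between them, (hydrogen in place of chloro on an aromatic carbon), therefore makes a step that the two limits leave unreadable from compound 1 to compound 2, as the limit of > 128000 nM in this assay, at which 2 of the 3 values shown sit, shows. Compound 3 gives 8160 nM in this assay. Compound 4 differs from compound 3 by hydrogen in place of chloro on an aromatic carbon, the same kind of change, though here the place is para to a large group rather than meta to a large group. Because a step that the two limits leave unreadable from compound 1 to compound 2 cannot be read, the expectation for compound 4 rests only on compound 3 and its 8160 nM, with a small step expected. Compound 4 is expected to give 12000 nM in this assay, between 4500 nM and 35000 nM, an estimated step of a 1.5-fold higher number from compound 3 to compound 4 (0.17 log units; within the scatter).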

Compound 4, half-maximal inhibitory concentration: 12600 nM
Compound 4: the middle estimate sits 1.1-fold (0.02 log units) below what was measured, within the range that was stated.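

In this assay, hydrogen in place of chloro on the core of compound 3 gives a 1.5-fold higher number from compound 3 to compound 4 (0.19 log units; within the scatter), so on this core the change from 4-chlorophenyl to phenyl cannot be told apart from repeat measurement. The same kind of change on the core of compound 1 cannot be read, since compound 1 and compound 2 give only limits of the assay: the limit of > 128000 nM in this assay, at which 2 of the 4 values shown sit. The series therefore does not show whether the change carries from one core to the other.

Still open, from the compounds shown here alone, is whether an amine or a carboxylic acid in place of the chloro of compound 3 would give a step beyond the scatter. Also open, going by these compounds, is whether either group would bring the core of compound 1 to a readable number.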